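Dimethyl Amide at the Pyrrole Carbonyl of the Shared Core

The source may hold more compounds than are shown below. What is called first, only, known or untested is meant among the compounds shown, and "the series" means these compounds.

Compound 1 `COc1cc(-n2cccc2C(=O)O)ccc1Nc1ncc(Cl)c(Nc2ccccc2NS(C)(=O)=O)n1` — 1060 nM
Compound 2 `COc1cc(-n2cccc2C(=O)NCCO)ccc1Nc1ncc(Cl)c(Nc2ccccc2NS(C)(=O)=O)n1` — > 10000 nM

In a functional assay on A549 cells (Homo sapiens) for antiproliferative activity, read by MTT assay, with a stated time of 72 h (a higher number here means a weaker inhibitor, a lower number a stronger inhibitor), compound 1 gives 1060 nM. Compound 2 reaches only the limit of this assay, > 10000 nM, so its true value is not known (the limit of > 10000 nM in this assay, at which 1 of the 2 values shown sits). Among the compounds with values here, the single measured step is an at least 9.4-fold higher number from compound 1 to compound 2 (0.97 log units; beyond the scatter), a change at the carbonyl carbon that sits on the pyrrole of the shared core. Compound 3 `COc1cc(-n2cccc2C(=O)N(C)C)ccc1Nc1ncc(Cl)c(Nc2ccccc2NS(C)(=O)=O)n1` is not yet measured; it differs from compound 2 by dimethylamino in place of (2-hydroxyethyl)amino on a carbonyl carbon. Within the data shown here, no measured pair tests this change directly, and the one measured step shows only that an amide built from (2-hydroxyethyl)amino is weaker than the acid of compound 1. Because compound 2 sits at a limit, the size of the step to compound 3 cannot be read from the numbers, and it is estimated as an at least 1.6-fold lower number from compound 2 to compound 3 (0.22 log units; that floor lies within the scatter). Compound 3 is expected to give about 6000 nM, within 1500 nM to 20000 nM, with a fair chance that only a limit is reported.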

Compound 3, half-maximal inhibitory concentration: > 10000 nM
Compound 3 gave a limit, no number; the forecaster's own chance of this, stated with the estimate: 40%; middle value at least 1.6-fold (0.22 log units) from the limit.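

At this carbonyl carbon a second amide repeats the loss: dimethylamino in place of hydroxy gives an at least 9.4-fold higher number from compound 1 to compound 3 (0.97 log units; beyond the scatter) in the same comparison with the acid. The loss therefore does not depend on the (2-hydroxyethyl)amino chain, since dimethylamino, with no hydrogen-bond donors, goes the same way, and among the compounds shown the acid of compound 1 alone gives a number. In this assay compound 3 gives > 10000 nM as a limit and not a number, so the step between the two amides cannot be read: the limit of > 10000 nM in this assay, at which 2 of the 3 values shown sit.

From the compounds shown here alone, how weak either amide truly is stays open. So does whether a methyl ester, or an amide of methylamine with its hydrogen kept on the nitrogen, at this carbonyl carbon would follow the acid or the two amides.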